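This account rests on a few compounds, and the source may have more. Where it says the series, first, only, none or still open, it means among the compounds named here.

Among the compounds with values here, compound 1 `C=C/C(C)=C\C=C\C(C)CC(=O)CC(C)C` is the only member of the series with a number in a functional assay on A549 cells (Homo sapiens) for cytotoxicity (on this read-out lower numbers stand for stronger inhibition and higher numbers for weaker inhibition), where compound 1 gives 2.5 ug/mL. Compound 2 `CC(C)=C/C=C\C(C)/C=C/C=C(\C)C=O` is reported in this assay only as a limit, > 10 ug/mL. Within the data shown here, of the two values shown, one sits at the limit of > 10 ug/mL in this assay, at which 1 of the 2 values shown sits, and no measured step between the two compounds can be drawn. Compound 3 `C=C/C(C)=C/C=C/C(C)CC(=O)CC(C)C` has not yet been tested in this assay. It differs from compound 1 by the two compounds have the same atoms and bonds; at least one stereo element is drawn with a configuration in one of them and without one in the other: 1 of 3 stereo elements differ; a double bond is drawn Z in compound 1 and E in compound 3. Among the measured compounds shown here, with no measured step available and the atoms and bonds unchanged, the step expected from compound 1 to compound 3, a 1.2-fold higher number from compound 1 to compound 3 (0.08 log units; within the scatter), is none beyond the usual scatter of the read-out. In this assay compound 3 is therefore estimated at 3 ug/mL, with a range from 1.2 ug/mL to 8 ug/mL that allows for the ordinary spread of repeated measurements.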

Compound 3, half-maximal inhibitory concentration: 5 ug/mL
For compound 3 the middle estimate is 1.7-fold (0.22 log units) below the measured one, and the stated range covers the measured number.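

Within the data shown here, the first measured step in this assay is a 2.0-fold higher number from compound 1 to compound 3 (0.30 log units; within the scatter), at the one double bond where the two structures differ. Among these compounds, compound 2 gives no such step, and its > 10 ug/mL is a limit. On this read-out, the drawn geometry at this double bond does not separate compound 1 from compound 3, although the comparison is not one between two fully defined forms, and the reading is qualified by this: the fact that one of compounds 1 and 3 is drawn with a defined configuration and the other without, at the place where they differ.

Still open, on these data alone, is how a carboxylic acid or an amine in place of the carbonyl of compound 1 would read in this assay. The compounds shown also leave open whether the geometry of the other double bond in compound 1 matters more than that of this one.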